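A few compounds are considered here, and "the series" means these few. Any claim that something is new, unique, unknown or untested is made for them only; others in the source may bear on it.

Working notes on the diaryl-alkyne series. Compound 1 `OCC#Cc1ccccc1C#Cc1ccccc1` in a functional assay on M14 cells (Homo sapiens) for cytotoxicity (on this read-out higher numbers stand for weaker inhibition of growth and lower numbers for stronger inhibition of growth), gives 10600 nM. Compound 2 `OCCC#Cc1ccccc1C#Cc1ccccc1` carries one more chain carbon before the hydroxy group, and in this assay compound 2 gives 16000 nM. The only measured step, a 1.5-fold higher number from compound 1 to compound 2 (0.18 log units; within the scatter), is within the scatter, so on the two numbers shown compound 2 sits alongside compound 1 with no separation that can be trusted.

Compound 3 `OCCCCC#Cc1ccccc1C#Cc1ccccc1` continues the same line of change: 2-hydroxyethyl in place of hydroxy on a saturated chain carbon, two bonds along the chain from a triple-bonded carbon. For the measured compounds named here, the one step that bears on it, lengthening the hydroxyalkyl chain by a single carbon, was a 1.5-fold higher number from compound 1 to compound 2 (0.18 log units; within the scatter) and did not move the number beyond the scatter. Extending the chain by two further carbons is therefore not expected to produce a step in this assay that is distinguishable from repeat measurements; if anything, a small drift toward a larger number, in line with the direction of a 1.5-fold higher number from compound 1 to compound 2 (0.18 log units; within the scatter), is expected. The step from compound 2 to compound 3 is thus estimated as a 1.3-fold higher number from compound 2 to compound 3 (0.10 log units; within the scatter). For compound 3 the expected value in this assay is 20000 nM, with a range from 8000 nM to 50000 nM.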

Compound 3, concentration for 50% growth inhibition: 10000 nM
The estimate for compound 3 lay 2.0-fold (0.30 log units) above the measured number; measured number inside the range.
By their numbers in this assay, from the lowest: compounds 3, 1 and 2 (each within the scatter of the next).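

Adding 2-hydroxyethyl in place of hydroxy on a saturated chain carbon, two bonds along the chain from a triple-bonded carbon, separates nothing in this assay (a 1.6-fold lower number from compound 2 to compound 3 (0.20 log units; within the scatter)), and this step points the opposite way to the earlier single-carbon step (a 1.5-fold higher number from compound 1 to compound 2 (0.18 log units; within the scatter)), so compounds 1, 2 and 3 show no trend with chain length. Across the whole span, the two ends of the set also stay within the scatter (a 1.1-fold lower number from compound 1 to compound 3 (0.03 log units; within the scatter)), which means that at this position the chain lengths shown give numbers that cannot be told apart. No supporting data bear on why these numbers stay together.

Going by these compounds, all three compounds keep the hydroxy group and the core of compound 1, so it remains open whether an amine or a carboxylic acid in place of that hydroxy group would give a number separable from these. On these data alone, it also remains open whether a longer chain would stay within the scatter of compound 3.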